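Fluoroalkyl for isopentyl on a sulfide core

The compounds below may be only part of what the source reports. "The series", "measured", "known", "first", "only" and "open" are said of these compounds alone.

Of the compounds shown here, three have been tested in an ADME assay on HEp-2 cells (Homo sapiens) for cytotoxicity; a higher number here means that more compound is tolerated, a lower number that less compound is tolerated. Compound 1 `CC(C)CCn1c(CN2C(=O)CSc3ccccc32)nc2ccccc21` gives 6780 nM, the lowest of the three numbers. Compound 3 `CC(C)CCn1c(CN2C(=O)CS(=O)(=O)c3ccccc32)nc2ccccc21` gives 63000 nM; the difference between the two cores is not broken down here. Compound 2 `O=C1CS(=O)(=O)c2ccccc2N1Cc1nc2ccccc2n1CCCCF` gives 211000 nM, and the step of a 3.3-fold higher number from compound 3 to compound 2 (0.52 log units; beyond the scatter) comes from one change, (2-fluoroethyl in place of isopropyl on a saturated chain carbon, two bonds along the chain from an aromatic nitrogen).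

Compound 4 `O=C1CSc2ccccc2N1Cc1nc2ccccc2n1CCCCF` has not yet been measured in this assay. It differs from compound 1 by the same change, (2-fluoroethyl in place of isopropyl on a saturated chain carbon, two bonds along the chain from an aromatic nitrogen), made on the core of compound 1 rather than that of compound 3. Within the data shown here, since that change gave a 3.3-fold higher number from compound 3 to compound 2 (0.52 log units; beyond the scatter), a step of similar size is expected for compound 4, a 3.2-fold higher number from compound 1 to compound 4 (0.51 log units; beyond the scatter), resting on only one measured pair. Compound 4 is therefore estimated at 22000 nM, with a range from 9000 nM to 55000 nM.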

Compound 4, half-maximal cytotoxic concentration: > 96300 nM
Compound 4: a limit, no number; the forecaster's own chance of this, stated with the estimate: 5%; middle value at least 4.3-fold (0.64 log units) away from the limit.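

In this assay compound 4 gives > 96300 nM, which is a limit of the assay and not a number. From the compounds shown here alone, the change reads as an at least 14-fold higher number from compound 1 to compound 4 (1.15 log units; beyond the scatter), so it raises the number on both cores, but the size of the step does not carry over from one core to the other: the same change on two cores in this assay, a 3.3-fold higher number (0.52 log units; beyond the scatter) from compound 3 to compound 2 and an at least 14-fold higher number (1.15 log units; beyond the scatter) from compound 1 to compound 4, at least 4.2-fold (0.62 log units) apart, beyond the scatter of two such steps Since the step on the core of compound 1 has only a lower bound, its full size stays unknown, and two pairs establish no rule for other cores.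

The compounds shown leave open whether a longer chain or an amine in place of the 2-fluoroethyl would also raise the number on these two cores.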